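Swapping 4-Methoxyphenyl for 2-Bromophenyl on a Carbonyl Carbon

The source may hold more compounds than are shown below. What is called first, only, known or untested is meant among the compounds shown, and "the series" means these compounds.

In a functional assay on A549 cells (Homo sapiens) for inhibition, read by MTT assay, with a stated time of 24 h (on this read-out lower numbers stand for stronger inhibition of growth and higher numbers for weaker inhibition of growth), compound 1 `COc1cccc(C(=O)n2c(-c3cn(C)c4ccc(Br)cc34)nc3ccccc32)c1` gives 10800 nM, and compound 2 `COc1ccc(C(=O)n2c(-c3cn(C)c4ccc(Br)cc34)nc3ccccc32)cc1` gives 11300 nM. These two numbers lie within the scatter of each other, so compound 2 stands level with compound 1 and neither can be ranked.

The next compound, compound 3 `Cn1cc(-c2nc3ccccc3n2C(=O)c2ccccc2Br)c2cc(Br)ccc21`, keeps the shared core and differs from compound 2 in one place: 2-bromophenyl in place of 4-methoxyphenyl on a carbonyl carbon. In short, 2-bromophenyl stands in place of 4-methoxyphenyl on a carbonyl carbon.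

Among the compounds with values here, only one measured step bears on this change: a 1.0-fold higher number from compound 1 to compound 2 (0.02 log units; within the scatter). It concerns the same carbonyl carbon and stays within the scatter, but it only exchanges 3-methoxyphenyl for 4-methoxyphenyl. Within the data shown here, no measured compound carries 2-bromophenyl, so the data give no direct guide to this group, and the expectation remains loose. In this assay no step beyond the scatter is expected, in either direction, and the expected change is a 1.1-fold lower number from compound 2 to compound 3 (0.05 log units; within the scatter). For compound 3 the estimated value is 10000 nM, with an expected range from 4000 nM to 25000 nM.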

Compound 3, concentration for 50% growth inhibition: 46700 nM
Compound 3: the middle estimate sits 4.7-fold (0.67 log units) below what was measured; the whole stated range lies below it.
By their numbers in this assay, from the lowest: compounds 1 and 2 (each within the scatter of the next); then compound 3.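

In this assay the change to 2-bromophenyl on the carbonyl carbon brings a 4.1-fold higher number from compound 2 to compound 3 (0.62 log units; beyond the scatter) and a 4.3-fold higher number from compound 1 to compound 3 (0.64 log units; beyond the scatter) as its two readings. Both steps are modest but beyond the scatter, which makes compound 3 the weakest inhibitor of growth of the three and shows that this position, silent when only 3-methoxyphenyl and 4-methoxyphenyl were exchanged, does respond when 2-bromophenyl enters. No measurement at hand accounts for this loss of inhibition.

The compounds shown cannot separate the effect of bringing in the bromine from that of losing the methoxy group, nor say whether the place of the bromine on the phenyl ring matters. On these data alone, it also remains open whether 3-bromophenyl, 4-bromophenyl, plain phenyl or a non-aromatic group such as cyclohexyl on the same carbonyl carbon would stand level with compound 1 and compound 2 or follow compound 3.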